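Methyl to Trifluoromethyl: Estimating Compound 3

A few compounds are considered here, and "the series" means these few. Any claim that something is new, unique, unknown or untested is made for them only; others in the source may bear on it.

Measured compounds:
Compound 1, `Cc1ccc(-c2nn(-c3ccccc3)cc2-c2nc3ccccc3n2S(=O)(=O)c2ccccc2)cc1`, gives 830 nM in a functional assay on MCF7 cells (Homo sapiens) for antiproliferative activity, read by MTT assay, with a stated time of 24 h; on this read-out higher numbers stand for weaker inhibition and lower numbers for stronger inhibition.
Compound 2, `Cc1ccc(-c2nn(-c3ccccc3)cc2-c2nc3ccccc3n2S(=O)(=O)c2ccc(Br)cc2)cc1`, gives 3160 nM.

For the measured compounds named here, compound 2 has the higher of the two numbers, meaning it is the weaker inhibitor of the pair; the only measured step is a 3.8-fold higher number from compound 1 to compound 2 (0.58 log units; beyond the scatter).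

Compound 3, `O=S(=O)(c1ccc(Br)cc1)n1c(-c2cn(-c3ccccc3)nc2-c2ccc(C(F)(F)F)cc2)nc2ccccc21`, has not been measured. It differs from compound 2 in one place: trifluoromethyl in place of methyl on an aromatic carbon. Going by the values given here, no measured step concerns this kind of change. Among the compounds with values here, the one step available, a 3.8-fold higher number from compound 1 to compound 2 (0.58 log units; beyond the scatter), involves a different group on a different ring, so it offers no direct guidance here, only a sign that single changes can move the number modestly.

With nothing bearing directly on the change, the expectation for compound 3 is a step of about a 1.1-fold higher number from compound 2 to compound 3 (0.04 log units; within the scatter), which stays within the scatter. Compound 3 is therefore estimated at 3500 nM, with a plausible range from 1200 nM to 10000 nM.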

Compound 3, half-maximal inhibitory concentration: 2470 nM
Beside the measured number, compound 3's estimate is 1.4-fold (0.15 log units) above it, and the stated range covers the measured number.
By their numbers in this assay, from the lowest: compound 1; then compounds 3 and 2 (each within the scatter of the next).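

In this assay, replacing the 4-methylphenyl of compound 2 with the 4-(trifluoromethyl)phenyl of compound 3 gives a 1.3-fold lower number from compound 2 to compound 3 (0.11 log units; within the scatter), so the two compounds cannot be told apart on this read-out. This position, on the aromatic ring and para to a large group, therefore accepts a group of four heavy atoms in place of one with no change beyond the usual scatter, unlike the bromo step on the other ring, a 3.8-fold higher number from compound 1 to compound 2 (0.58 log units; beyond the scatter). No measurement here explains why this exchange leaves the number so close.

The compounds shown leave open whether an amine, a carboxylic acid or a longer chain at this position would read the same. They also leave open whether the same exchange would give a similar result without the bromo group.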